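Two trimethoxyphenyl pyrazole chalcones at the assay limit

This account rests on a few compounds, and the source may have more. Where it says the series, first, only, none or still open, it means among the compounds named here.

Measured so far:
compound 1 `COc1cc(-c2cc(/C=C/C(=O)c3ccc(N)cc3)[nH]n2)cc(OC)c1OC` — > 100000 nM
compound 2 `COc1ccc(C(=O)/C=C/c2cc(-c3cc(OC)c(OC)c(OC)c3)n[nH]2)cc1` — > 100000 nM

In a functional assay on CCRF-CEM cells (Homo sapiens) for inhibition, read by sulforhodamine B assay, with a stated time of 48 h (on this read-out lower numbers stand for higher toxicity in this test and higher numbers for lower toxicity in this test), compound 1 returns only a limit, > 100000 nM. In this assay compound 2 likewise returns only a limit, > 100000 nM. Going by the values given here, the single step between them, a step that the two limits leave unreadable from compound 1 to compound 2, therefore cannot be read, and the shared core of compound 2 gives no number on which compound 2 could be placed other than that it sits at the limit of > 100000 nM in this assay, at which 2 of the 2 values shown sit.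

Compound 3 `COc1cc(-c2cc(/C=C/C(=O)c3ccc(F)c(F)c3)[nH]n2)cc(OC)c1OC` is not yet measured. It differs from compound 2 in one place: 3,4-difluorophenyl in place of 4-methoxyphenyl on a carbonyl carbon. Among the compounds with values here, no measured step bears on this change; the only step recorded, a step that the two limits leave unreadable from compound 1 to compound 2, touches a different group and is itself unreadable. There is thus no basis for expecting a step beyond the scatter in either direction, and the expected outcome for compound 3 is again a limit.

Compound 3 is estimated at 100000 nM in this assay, with a range of 30000 nM to 300000 nM. The step this estimate implies, a number no higher from compound 2 to compound 3 (the limit leaves the size open), is expected to be none beyond the scatter.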

Compound 3, concentration lethal to 50% of the cells: > 100000 nM
Compound 3 gave a limit, no number; the forecaster's own chance of this, stated with the estimate: 70%; the middle value sits exactly at the limit.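

In this assay compound 3 returns only a limit, > 100000 nM, so its steps from compound 1 and compound 2 cannot be read. The compounds shown leave open whether any group on the carbonyl carbon gives a readable value in this assay, and how 4-aminophenyl, 4-methoxyphenyl and 3,4-difluorophenyl would then compare.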